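The source may report more compounds than this note shows. Statements on the series, on what has been measured and on what is new or still open speak of the compounds shown alone.

Working notes on the series in an ADME assay on microsomes from liver (Rattus norvegicus) for metabolic stability; on this read-out higher numbers stand for fast clearance and lower numbers for slow clearance. Compound 1 (`Cn1cc(C(=O)Nc2ccc(-c3ccccc3)c(C(F)(F)F)c2)c(=O)c2ccccc21`) reads < 14 mL.min-1.g-1, which is a limit of the assay. Compound 2 (`Cn1cc(C(=O)Nc2ccc(-c3ccccn3)c(C(F)(F)F)c2)c(=O)c2ccccc21`) reads < 14 mL.min-1.g-1, also a limit and not a number. The record so far is the limit of < 14 mL.min-1.g-1 in this assay, at which 2 of the 2 values shown sit. Compound 3 (`Cn1cc(C(=O)Nc2ccc(-c3cccnc3)c(C(F)(F)F)c2)c(=O)c2ccccc21`) differs from compound 2 by pyridin-3-yl in place of pyridin-2-yl on an aromatic carbon. Going by the values given here, the only measured step bearing on this is a step that the two limits leave unreadable from compound 1 to compound 2, so it provides no size or direction to carry over. In this assay, no change beyond the scatter is expected, and the estimated step is a step that the limit leaves unreadable from compound 2 to compound 3. Compound 3 is expected at 12 mL.min-1.g-1, with an estimated range of 6 mL.min-1.g-1 to 22 mL.min-1.g-1.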

Compound 3, intrinsic clearance in microsomes in the Rattus norvegicus assay: 18 mL.min-1.g-1
For compound 3 the middle estimate is 1.5-fold (0.18 log units) below the measured one; low and high end bracket the measured number.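

In the Rattus norvegicus assay, pyridin-3-yl at this position, ortho to a trifluoromethyl group, gives the first actual number rather than a limit, with an at least 1.2-fold higher number from compound 2 to compound 3 (0.10 log units; that floor lies within the scatter) and an at least 1.2-fold higher number from compound 1 to compound 3 (0.10 log units; that floor lies within the scatter). Both floors lie within the scatter, so neither step yet shows a real rise in clearance. In a physicochemical assay for solubility, in phosphate buffer, at pH 7.4 (a higher number here means a more soluble compound, a lower number a less soluble compound), compound 2 reads < 1 ug/mL, which is a limit. In the physicochemical assay, compound 3 reads < 1 ug/mL, also a limit. In the physicochemical assay, the step for the same change cannot be read, as both compounds sit at a limit: the limit of < 1 ug/mL in the physicochemical assay, at which 2 of the 2 values shown sit.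

On these data alone, the true size of both steps in the Rattus norvegicus assay stays open. Also open, as far as these compounds go, is how an amine or a carboxylic acid on the pyridine ring would read in the Rattus norvegicus assay and the physicochemical assay.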